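The compounds below may be only part of what the source reports. "The series", "measured", "known", "first", "only" and "open" are said of these compounds alone.

Working notes on the series, read in an ADME assay on L02 cells (Homo sapiens) for antiproliferative activity, read by MTT assay, with a stated time of 48 h; a lower number here means a stronger inhibitor, a higher number a weaker inhibitor. Compound 1 (`C#CCCOC(=O)c1ccc(C(CC)(CC)c2ccc(OCCC(O)(CC)CC)c(C)c2)n1CC`) gives > 50000 nM, which is a limit of the assay and not a number; the limit of > 50000 nM in this assay, at which 1 of the 2 values shown sits, is the only line of this kind so far. Going by the values given here, compound 2 (`CCn1c(C(=O)NC(CC(=O)O)C(=O)OC)ccc1C(CC)(CC)c1ccc(OCCC(O)(CC)CC)c(C)c1`) gives 7590 nM, the only true number, so it cannot yet be ranked against a spread of values.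

Compound 3 (`CCn1c(C(=O)NC(C)CO)ccc1C(CC)(CC)c1ccc(OCCC(O)(CC)CC)c(C)c1`) keeps the shared core and differs from compound 2 by a group of 4 heavy atoms (3 carbon, 1 oxygen; no ring) in place of a group of 9 heavy atoms (5 carbon, 4 oxygen; no ring), on an amide-type nitrogen. The entering group is 1-(hydroxymethyl)ethyl, on an amide-type nitrogen.

Among the compounds with values here, one measured step bears on this: an at least 6.5-fold lower number from compound 1 to compound 2 (0.81 log units; beyond the scatter). Going by these compounds, it is at least modest, its true size is unknown given the limit at one end, and it came with a larger group on a carbonyl carbon. The present change goes to a smaller group at a different place, so that step is only a loose guide. On the strength of it, a modest move towards a higher number is expected. The expected step is a 2.0-fold higher number from compound 2 to compound 3 (0.30 log units; within the scatter). For compound 3 the estimated value is 15000 nM. The expected range for compound 3 runs from 5000 nM to 50000 nM.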

Compound 3, half-maximal inhibitory concentration: 4840 nM
For compound 3 the middle estimate is 3.1-fold (0.49 log units) above the measured one; the measured number lies below the stated range.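

In this assay, 1-(hydroxymethyl)ethyl in place of the group of 9 heavy atoms on the amide-type nitrogen gives a 1.6-fold lower number from compound 2 to compound 3 (0.20 log units; within the scatter), so this much smaller group and the larger one are not told apart at this position. On the carbonyl carbon, (1-(hydroxymethyl)ethyl)amino in place of (but-3-yn-1-yl)oxy gives an at least 10-fold lower number from compound 1 to compound 3 (1.01 log units; beyond the scatter), which makes compound 3 the second compound with an amide-type nitrogen on that carbonyl carbon to stand beyond the scatter from compound 1, after compound 2. The true size of this step stays unknown because compound 1 sits at a limit of the assay and not at a number: the limit of > 50000 nM in this assay, at which 1 of the 3 values shown sits.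

The compounds shown leave open whether a plain ethyl or longer alkyl chain, a simple carboxylic acid or an amine on the amide-type nitrogen would move the number in this assay beyond the scatter. Going by these compounds alone, with only two groups on that nitrogen to compare, neither the role of the hydroxyl in 1-(hydroxymethyl)ethyl nor any trend with group size can be drawn.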